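Swapping Benzyloxy for Ethoxy in a Sulfonylurea Series

A few compounds are considered here, and "the series" means these few. Any claim that something is new, unique, unknown or untested is made for them only; others in the source may bear on it.

Values so far in a functional assay on thoracic aorta (Rattus norvegicus, strain Wistar), with a stated time of 15 min; a lower number here means that less compound is needed, a higher number that more compound is needed for the effect (half-maximal effective concentrations):
- Compound 1 `CCOc1ccc(F)cc1C(C)NC(=O)N(C)S(=O)(=O)c1ccc(C)cc1` gives 7800 nM as its value
- Compound 2 `CCOc1ccc(Cl)cc1C(C)NC(=O)NS(=O)(=O)c1ccc(C)cc1` gives > 300000 nM as a limit of the assay, not a number
- Compound 3 `Cc1ccc(S(=O)(=O)N(C)C(=O)NC(C)c2cc(Br)ccc2OCc2ccccc2)cc1` gives 67100 nM as its value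

Only two of these results are true numbers, and a lower number means that less compound is needed for the effect. Compound 3 (67100 nM) holds the higher of the two, and its gap to compound 1 (7800 nM) lies beyond the usual scatter. Compound 2 has only a limit (> 300000 nM) and no number.

Compound 4 `CCOc1ccc(Br)cc1C(C)NC(=O)N(C)S(=O)(=O)c1ccc(C)cc1` differs from compound 3 in one place (methyl in place of phenyl on a saturated chain carbon bound to an oxygen on an aromatic ring): methyl in place of phenyl on a saturated chain carbon bound to an oxygen on an aromatic ring, which reads as benzyloxy to ethoxy. For the measured compounds named here, no measured pair shows this change on its own, so the expectation leans on compound 1 (7800 nM), which also carries ethoxy. A clear step towards a lower number in this assay is therefore expected, larger than the scatter but uncertain in size. The estimated step runs an 8.4-fold lower number from compound 3 to compound 4 (0.92 log units; beyond the scatter) in this expectation. Compound 4 is expected near 8000 nM with 2000 nM to 30000 nM as the estimated range.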

Compound 4, half-maximal effective concentration: 28600 nM
For compound 4 the middle estimate is 3.6-fold (0.55 log units) below the measured one; the measured number falls inside the stated range.
By their numbers in this assay, from the lowest: compound 1; then compound 4; then compound 3. At a limit, above all of these: compound 2.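

In this assay, the swap from benzyloxy to ethoxy now has a measured size of its own: it gives a 2.3-fold lower number from compound 3 to compound 4 (0.37 log units; beyond the scatter), a modest step that lies beyond the usual scatter. For the compounds shown here, the halogen on the aromatic carbon can also be read as a single change for the first time, since bromo in place of fluoro gives a 3.7-fold higher number from compound 1 to compound 4 (0.56 log units; beyond the scatter), another modest step but in the opposite direction, so within these pairs ethoxy gives the lower number than benzyloxy and fluoro the lower number than bromo. Nothing measured here gives a cause for either step.

As far as these compounds go, it remains open whether a shorter methoxy group, or an amine in place of the oxygen on the aromatic ring, would move the number further, and whether the benzyloxy-to-ethoxy step keeps its size with fluoro on the aromatic carbon instead of bromo. Compound 2 holds only a limit and not a number, so no step to it can be read: the limit of > 300000 nM in this assay, at which 1 of the 4 values shown sits.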